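The source may hold more compounds than are shown below. What is called first, only, known or untested is meant among the compounds shown, and "the series" means these compounds.

Working notes on the series, read in a functional assay on K562 cells (Homo sapiens) for antiproliferative activity, with a stated time of 72 h; on this read-out higher numbers stand for weaker inhibition and lower numbers for stronger inhibition. Compound 1 `OC[C@H]1O[C@@H](n2cnc3c(NCc4cccc(F)c4)ncnc32)[C@H](O)[C@@H]1O` gives 7600 nM and compound 2 `OC[C@H]1O[C@@H](n2cnc3c(NCc4ccc(F)c(Cl)c4)ncnc32)[C@H](O)[C@@H]1O` gives 5500 nM. Compound 3 `Cc1ccc(O)c(CNc2ncnc3c2ncn3[C@@H]2O[C@H](CO)[C@@H](O)[C@H]2O)c1` gives 16500 nM, the highest number of the three.

Compound 4 `OC[C@H]1O[C@@H](n2cnc3c(NCc4cccc(C(F)(F)F)c4)ncnc32)[C@H](O)[C@@H]1O` is not yet measured. It places 3-(trifluoromethyl)phenyl in place of 2-hydroxy-5-methylphenyl on a saturated chain carbon bound to a nitrogen on an aromatic ring.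

Going by the values given here, two steps bear on this, both modest and both running the opposite way: a 2.2-fold higher number from compound 1 to compound 3 (0.34 log units; beyond the scatter), and a 3.0-fold higher number from compound 2 to compound 3 (0.48 log units; beyond the scatter). Among the fluorine-bearing phenyl groups, the only measured step is a 1.4-fold lower number from compound 1 to compound 2 (0.14 log units; within the scatter). A modest fall in the number is therefore expected, bringing compound 4 near the values of compound 1 and compound 2.

The expected step is a 2.4-fold lower number from compound 3 to compound 4 (0.37 log units; beyond the scatter). Compound 4 is estimated at 7000 nM, with an expected range of 3000 nM to 16000 nM.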

Compound 4, half-maximal inhibitory concentration: > 166000 nM
Compound 4 ended at the assay's limit; the forecaster's own chance of this, stated with the estimate: 5%; at least 23-fold (1.37 log units) between middle value and limit.
By their numbers in this assay, from the lowest: compounds 2 and 1 (each within the scatter of the next); then compound 3. At a limit, above all of these: compound 4.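

Compound 4 reads only as a limit in this assay, not as a number: the limit of > 166000 nM in this assay, at which 1 of the 4 values shown sits. The position therefore does not treat all fluorine-bearing groups alike: trifluoromethyl in place of fluoro gives an at least 21-fold higher number from compound 1 to compound 4 (1.33 log units; beyond the scatter). The other two steps, an at least 30-fold higher number from compound 2 to compound 4 (1.47 log units; beyond the scatter) and an at least 10-fold higher number from compound 3 to compound 4 (1.00 log units; beyond the scatter), are also larger than any step among the first three compounds, so this change reaches much further than the earlier changes on the phenyl ring.

On these data alone, whether methoxy or nitrile in place of trifluoromethyl would stay near compound 1 or reach the limit remains open. The same holds for an amine or a carboxylic acid on the phenyl ring.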